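Vinyl sulfone series: aryl swap on the alkene carbon

A few compounds are considered here, and "the series" means these few. Any claim that something is new, unique, unknown or untested is made for them only; others in the source may bear on it.

Measured so far in a functional assay on DU-145 cells (Homo sapiens) for inhibition, read by trypan blue exclusion, with a stated time of 96 h; a lower number here means a stronger inhibitor of growth, a higher number a weaker inhibitor of growth:
- compound 1 `COc1ccccc1/C=C(\C(=O)c1ccc(Br)cc1)S(=O)(=O)c1ccc(C)cc1` gives 1000 nM
- compound 2 `Cc1ccc(S(=O)(=O)/C(=C/c2ccccc2OCc2ccccc2)C(=O)c2ccc(Br)cc2)cc1` gives 1000 nM
- compound 3 `O=C(/C(=C\c1ccc(F)cc1F)S(=O)(=O)c1ccc(Cl)cc1)c1ccc(Br)cc1` gives 25000 nM

Compound 1 stands level with compound 2 at the digits given, and together these two are the lowest of the three numbers; compound 3 lies furthest off, and its gap to compound 1 is beyond the scatter. Compound 3 differs from compound 1 in two places at once, so that gap cannot be assigned to either.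

Within the data shown here, the one single-place step, no change at the digits printed from compound 1 to compound 2 (within the scatter), shows that a larger group on the oxygen of the aryl ring leaves the number unchanged within the scatter.

Compound 4 `Cc1ccc(S(=O)(=O)/C(=C/c2ccc(N(C)C)cc2)C(=O)c2ccc(Br)cc2)cc1` is not yet measured. It differs from compound 1 as follows: 4-(dimethylamino)phenyl in place of 2-methoxyphenyl on a double-bonded chain carbon bound to a double-bonded chain carbon. Among the measured compounds shown here, no measured step exchanges this aryl ring for another while holding everything else fixed, so the only guide is the tolerance seen in the step from compound 1 to compound 2, which bears on a different position of the same ring. On that basis a step of no more than the scatter is expected, with a wide range to cover the unknown ring exchange: a 1.5-fold higher number from compound 1 to compound 4 (0.18 log units; within the scatter). The estimate for compound 4 in this assay is 1500 nM, expected to fall between 400 nM and 8000 nM.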

Compound 4, concentration for 50% growth inhibition: 50000 nM
Beside the measured number, compound 4's estimate is 33-fold (1.52 log units) below it, outside the stated range (above it).
By their numbers in this assay, from the lowest: compounds 1 and 2 (each within the scatter of the next); then compounds 3 and 4 (each within the scatter of the next).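

In this assay, among these compounds, 4-(dimethylamino)phenyl in place of 2-methoxyphenyl on a double-bonded chain carbon bound to a double-bonded chain carbon gives a 50-fold higher number from compound 1 to compound 4 (1.70 log units; beyond the scatter), the first large single-place step. The ring itself is therefore sensitive to exchange, whereas no change at the digits printed from compound 1 to compound 2 (within the scatter) covers only phenyl added on the group at the ring oxygen and says nothing about replacing the whole aryl group. Nothing available explains the higher number for compound 4.

The step removes the methoxy group and brings in the dimethylamino group at once, so it remains open which of the two accounts for the change. A plain phenyl ring, or a ring carrying a primary amine or a carboxylic acid in place of dimethylamino, would help separate these contributions.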